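This account rests on a few compounds, and the source may have more. Where it says the series, first, only, none or still open, it means among the compounds named here.

Three compounds have numbers in a functional assay on MDA-MB-231 cells (Homo sapiens) for antiproliferative activity, read by MTT assay, with a stated time of 48 h; on this read-out lower numbers stand for stronger inhibition and higher numbers for weaker inhibition. Compound 1 `C=CS(=O)(=O)N1CCN(c2ncnc3ccc(-c4ccccc4)cc23)CC1` gives 47900 nM, compound 2 `C=CS(=O)(=O)N1CCN(c2ncnc3sc(-c4cccc5ncccc45)cc23)CC1` gives 21000 nM, and compound 3 `C=CS(=O)(=O)N1CCN(c2ncnc3sc(-c4cn(S(=O)(=O)c5ccccc5)c5ccccc45)cc23)CC1` gives 40400 nM. Compound 2 stands clearly apart only from compound 1, whose number is higher by more than the usual scatter of repeated measurements. Compound 2 and compound 3 lie within that scatter of each other, so these two cannot be told apart.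

Compound 4 `C=CS(=O)(=O)N1CCN(c2ncnc3sc(C4=CCCCC4)cc23)CC1` has not been measured yet. It keeps the core of compound 2 but carries cyclohex-1-en-1-yl in place of quinolin-5-yl on an aromatic carbon, next to the ring sulfur: cyclohex-1-en-1-yl in place of quinolin-5-yl on an aromatic carbon.

For the measured compounds named here, no two measured compounds differ in one place only, so no measured step shows directly what such a swap does. The closest guide is compound 3, which has a very different group on this carbon and gives 40400 nM, within the scatter of compound 2. On that basis, no step beyond the scatter is expected in this assay, perhaps only a slight drift towards a higher number. The estimated step is a 1.4-fold higher number from compound 2 to compound 4 (0.15 log units; within the scatter). Compound 4 is expected at about 30000 nM, with an estimated range from 12000 nM to 75000 nM.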

Compound 4, half-maximal inhibitory concentration: > 50000 nM
Compound 4 ended at the assay's limit; the forecaster's own chance of this, stated with the estimate: 15%; middle value at least 1.6-fold (0.22 log units) away from the limit.
By their numbers in this assay, from the lowest: compounds 2, 3 and 1 (each within the scatter of the next, the first and the last beyond it). At a limit, above all of these: compound 4.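

For the compounds shown here, this result gives the first single change at this position with a readable size. In this assay, putting cyclohex-1-en-1-yl in place of quinolin-5-yl on the aromatic carbon next to the ring sulfur gives an at least 2.3-fold higher number from compound 2 to compound 4 (0.37 log units; beyond the scatter), so the group on this carbon does affect the read-out, and this swap comes with weaker inhibition. The value of compound 4 is a limit and not a number: the limit of > 50000 nM in this assay, at which 1 of the 4 values shown sits.

The compounds shown leave open which part of quinolin-5-yl matters, since the swap changes its nitrogen, its two aromatic rings and its number of heavy atoms all at once. A saturated cyclohexyl ring, a pyridin-3-yl ring or a small amine such as morpholine on this same carbon would help to separate these features, and would show whether any group here can give stronger inhibition than compound 2 does at 21000 nM.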